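This account rests on a few compounds, and the source may have more. Where it says the series, first, only, none or still open, it means among the compounds named here.

Working notes on the series. Compound 1 `Cc1nn(-c2ncnc3nc[nH]c23)c2c1C(OCc1ccc(C#N)cc1)CC(=O)N2` and compound 2 `Cc1nn(-c2ncnc3nc[nH]c23)c2c1C(OCc1ccccc1Cl)CC(=O)N2` share a core and differ only in the group on the saturated chain carbon bound to an oxygen on a saturated carbon. In a functional assay on HEK293 cells for agonist activity at G-protein coupled receptor 39 (Homo sapiens), read by scintillation proximity assay and inositol phosphate accumulation, with a stated time of 75 min (on this read-out lower numbers stand for an effect already at smaller amounts and higher numbers for an effect only at larger amounts of compound), compound 1 gives 60 nM and compound 2 gives 47 nM; the step of a 1.3-fold lower number from compound 1 to compound 2 (0.11 log units; within the scatter) lies within the scatter, so the two compounds are not separated by the read-out. Compound 2 therefore holds the lowest of the two numbers but stands level with compound 1.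

Compound 3 `Cc1nn(-c2ncnc3nc[nH]c23)c2c1C(OCC(C)C)CC(=O)N2` carries the change (isopropyl in place of 2-chlorophenyl on a saturated chain carbon bound to an oxygen on a saturated carbon). Within the data shown here, the only measured step, the one from compound 1 to compound 2, swaps one aromatic ring for another and bears only loosely on a move from an aromatic ring to a chain; no measured pair shows that move. With the ring gone, a higher number is expected for compound 3, and the step of a 3.8-fold higher number from compound 2 to compound 3 (0.58 log units; beyond the scatter) is estimated with wide uncertainty. For compound 3 in this assay an expected value of 180 nM is set, with a range from 50 nM to 700 nM.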

Compound 3, half-maximal effective concentration: 111 nM
Compound 3: middle estimate off by 1.6-fold (0.21 log units), on the high side; low and high end bracket the measured number.
By their numbers in this assay, from the lowest: compounds 2, 1 and 3 (each within the scatter of the next, the first and the last beyond it).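

In this assay the place on a saturated chain carbon bound to an oxygen on a saturated carbon now carries a group without a ring: isopropyl in place of 2-chlorophenyl gives a 2.4-fold higher number from compound 2 to compound 3 (0.37 log units; beyond the scatter) as a modest step beyond the scatter. Isopropyl in place of 4-cyanophenyl gives a 1.9-fold higher number from compound 1 to compound 3 (0.27 log units; within the scatter) and stays within the scatter, so among these three compounds an aromatic ring at this place is not needed for a value in this range, and the cost of removing it can be read only against compound 2. Nothing on hand gives a reason for either step.

The compounds shown leave open how a longer chain, an amine or a carboxylic acid would read at this place. They also leave open whether a ring other than those in compound 1 and compound 2 would separate from either one.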